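This account rests on a few compounds, and the source may have more. Where it says the series, first, only, none or still open, it means among the compounds named here.

Compound 1 `COC(=O)c1nc(C)n(-c2ccc(OC)cc2)n1`: in a functional assay on NCI-H226 cells (Homo sapiens) for inhibition, read by MTT assay, with a stated time of 72 h (on this read-out higher numbers stand for weaker inhibition of growth and lower numbers for stronger inhibition of growth), compound 1 gives > 100000 nM, a limit of the assay.
Compound 2 `COC(=O)c1nc(C)n(-c2ccc(Cl)cc2)n1`: in this assay compound 2 gives 84000 nM.

Among the measured compounds shown here, compound 2 stands as the only numbered value here; the entry for compound 1 is a limit (the limit of > 100000 nM in this assay, at which 1 of the 2 values shown sits). For the measured compounds named here, the single measured step, an at least 1.1-fold lower number from compound 1 to compound 2 (0.07 log units; that floor lies within the scatter), replaces methoxy with chloro. Compound 3 `COC(=O)c1nc(C)n(-c2ccc(F)cc2)n1` differs from compound 2 by fluoro in place of chloro on an aromatic carbon. That measured step does not exchange one halogen for another, so it gives little guidance, and no shift beyond the scatter in this assay is expected. Compound 3 is therefore estimated at 95000 nM (range 40000 nM to 250000 nM), an expected step of a 1.1-fold higher number from compound 2 to compound 3 (0.05 log units; within the scatter).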

Compound 3, concentration for 50% growth inhibition: 11700 nM
For compound 3 the middle estimate is 8.1-fold (0.91 log units) above the measured one; measured number outside the range, below it.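

On the aromatic carbon para to a large group, the choice of halogen matters in this assay: fluoro in place of chloro gives a 7.2-fold lower number from compound 2 to compound 3 (0.86 log units; beyond the scatter). Fluoro in place of methoxy gives an at least 8.5-fold lower number from compound 1 to compound 3 (0.93 log units; beyond the scatter), whereas the floor of the earlier step from methoxy to chloro lay within the scatter. That step is only a floor, as compound 1 stands at a limit: the limit of > 100000 nM in this assay, at which 1 of the 3 values shown sits.

Going by these compounds, what a nitrile or an amine would do at this carbon stays open, as does the effect of a carboxylic acid in place of the methyl ester.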